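Series notes: the substituent on the amine nitrogen

This account rests on a few compounds, and the source may have more. Where it says the series, first, only, none or still open, it means among the compounds named here.

Compound 1 `CCCCNC(=S)NC1=C(C#N)C(c2ccc(Cl)cc2Cl)C2=C(CCCC2=O)N1c1ccc(S(N)(=O)=O)cc1` is measured in a functional assay on Ehrlich cells (Mus musculus) for cytotoxicity, read by trypan blue exclusion, with a stated time of 2 h, tested at 10 ug/mL (on this read-out higher numbers stand for a stronger effect at the one concentration tested and lower numbers for a weaker effect), and gives 30%. Going by the values given here, compound 2 `N#CC1=C(NC(=S)Nc2ccc(Br)cc2)N(c2ccc(S(N)(=O)=O)cc2)C2=C(C(=O)CCC2)C1c1ccc(Cl)cc1Cl` gives 50% in this assay, the higher of the two numbers so far; the one measured step, a number 20 percentage points higher from compound 1 to compound 2 (beyond the scatter), comes from the change on the amide-type nitrogen and is the only guide to that position. Compound 3 `N#CC1=C(NC(N)=O)N(c2ccc(S(N)(=O)=O)cc2)C2=C(C(=O)CCC2)C1c1ccc(Cl)cc1Cl` is not yet measured. It differs from compound 2 as follows: a group of 3 heavy atoms (1 carbon, 1 nitrogen, 1 oxygen; no ring) in place of a group of 10 heavy atoms (7 carbon, 1 nitrogen, 1 sulfur, 1 bromine; one six-membered aromatic ring of carbon only), on an amine nitrogen. The step from compound 1 to compound 2 bears on this change only in that it shows the group on this nitrogen moves the number, and it did so by a modest amount when the aromatic ring entered; here that ring leaves and a far smaller group enters, so a decrease of similar size, rather than no change, is expected, giving a number 20 percentage points lower from compound 2 to compound 3 (beyond the scatter). Compound 3 is therefore estimated at 30% in this assay, within a range from 15% to 45%.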

Compound 3, a percentage reported as activity, at one concentration (the size of the read-out at that concentration, not a potency): 20%
Beside the measured number, compound 3's estimate is 10 percentage points above it, and the stated range covers the measured number.
By their numbers in this assay, from the lowest: compounds 3 and 1 (each within the scatter of the next); then compound 2.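

In this assay, the same kind of change at this amine nitrogen reads differently depending on the group that leaves: a number 30 percentage points lower from compound 2 to compound 3 (beyond the scatter), whereas a number 10 percentage points lower from compound 1 to compound 3 (within the scatter). Among the groups shown, only the one carrying the 4-bromophenyl ring in compound 2 stands apart, while the ring-free groups of compound 1 and compound 3 cannot be told apart. Within these ring-free groups, the drop from 7 to 3 heavy atoms does not register beyond the scatter.

Both steps also exchange sulfur for oxygen, so a carbamoyl group bearing 4-bromophenyl on its nitrogen would be needed to separate the loss of the ring from that exchange. No available evidence bears on the reason for these differences.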